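Methyl to Methoxy: Estimating Compound 3 Before Measurement

This account rests on a few compounds, and the source may have more. Where it says the series, first, only, none or still open, it means among the compounds named here.

Measured so far:
compound 1, `Cc1ccc(NC(=S)N/N=C/c2cccs2)cc1`: 16800 nM
compound 2, `C=CCNC(=S)N/N=C/c1cccs1`: > 100000 nM

Of the compounds shown here, two share a core and have been tested in a functional assay on UACC-62 cells (Homo sapiens) for inhibition, read by sulforhodamine B assay, with a stated time of 48 h; a lower number here means a stronger inhibitor of growth, a higher number a weaker inhibitor of growth. Compound 1 `Cc1ccc(NC(=S)N/N=C/c2cccs2)cc1` carries a methyl group on its six-membered aromatic ring of carbon only, and in this assay compound 1 gives 16800 nM. Compound 2 `C=CCNC(=S)N/N=C/c1cccs1` replaces that ring with an allyl chain; in this assay compound 2 gives > 100000 nM, which is a limit of the assay and not a number. Compound 2 therefore sits at the limit of > 100000 nM in this assay, at which 1 of the 2 values shown sits. Going by the values given here, compound 1 thus stands as the only real number in the set, with the remaining value being a limit.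

Compound 3 `COc1ccc(NC(=S)N/N=C/c2cccs2)cc1` has not yet been measured. It differs from compound 1 by methoxy in place of methyl on an aromatic carbon. Among the compounds with values here, no measured pair shows this kind of change, so there is nothing to draw a direction from. The step from compound 1 to compound 3 is expected to stay within the usual scatter, a 1.1-fold lower number from compound 1 to compound 3 (0.05 log units; within the scatter). Compound 3 is therefore estimated at about 15000 nM, with a likely range from 5000 nM to 60000 nM.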

Compound 3, concentration for 50% growth inhibition: > 100000 nM
Compound 3 gave a limit, no number; the forecaster's own chance of this, stated with the estimate: 15%; middle value at least 6.6-fold (0.82 log units) away from the limit.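

In this assay, putting methoxy in place of methyl on the six-membered aromatic ring, para to a large group, gives an at least 5.9-fold higher number from compound 1 to compound 3 (0.77 log units; beyond the scatter), so this position does not tolerate every small group equally. The earlier compounds shown here could not show this, since the allyl chain of compound 2 replaces the whole aromatic ring and so says nothing about a single group on that ring; here, one exchange at one position is enough to separate a measurable growth inhibitor from a compound that reaches the limit. Compound 3 gives > 100000 nM, which is a limit of the assay and not a number, and this makes the limit the most common result in the set: the limit of > 100000 nM in this assay, at which 2 of the 3 values shown sit.

Going by these compounds alone, with compound 1 as the only compound that gives a real number, the data do not say why methoxy and methyl differ here, or how far the true value of compound 3 lies beyond the limit. Going by these compounds, it also remains open how the ring would behave with a plain hydrogen, a chlorine atom, an amine or a longer chain such as ethyl at this position, and whether any of these would match or improve on the methyl group.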